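From propyl to cyclobutyl on the amine nitrogen

The source may hold more compounds than are shown below. What is called first, only, known or untested is meant among the compounds shown, and "the series" means these compounds.

Two close relatives have so far been compared in an ADME assay on liver (Homo sapiens) for metabolic stability, read by LC-MS, using microsomes and NADPH; on this read-out higher numbers stand for a more stable compound and lower numbers for a less stable compound. Compound 1 `CCCN(Cc1ccc(OCCn2c(=O)ccn(C)c2=O)c(C)c1)C(CC(=O)O)c1ccc(Cl)cc1` gives a reading of 30% on this test, while compound 2 `CCCN(Cc1ccc(OCCn2c(=O)ccn(C)c2=O)c(OC)c1)C(CC(=O)O)c1ccc(Cl)cc1` gives 61% and holds the higher of the two numbers. Within the data shown here, the only measured step (a number 31 percentage points higher from compound 1 to compound 2 (beyond the scatter)) was large and beyond the scatter, and it came from methoxy in place of methyl on an aromatic carbon.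

Compound 3 `COc1cc(CN(C2CCC2)C(CC(=O)O)c2ccc(Cl)cc2)ccc1OCCn1c(=O)ccn(C)c1=O` keeps that methoxy and changes something else: cyclobutyl in place of propyl on an amine nitrogen. Among the measured compounds shown here, no measured pair tests a change on that nitrogen, so the one known step bears on this change only loosely, and its size cannot simply be carried over. The safest starting point is therefore compound 2 itself, and no step beyond the scatter is expected in this assay. The expected step is small (a number 3 percentage points higher from compound 2 to compound 3 (within the scatter)). The estimated value for compound 3 is 64% within an expected range from 42% to 82% (an estimate that only a measurement can settle).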

Compound 3, percent of the compound remaining: 61%
The estimate for compound 3 lay 3 percentage points above the measured number, and the stated range covers the measured number.
By their numbers in this assay, from the lowest: compound 1; then compounds 2 and 3 (each within the scatter of the next).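

In this assay, cyclobutyl in place of propyl on the amine nitrogen gives no change at the digits printed from compound 2 to compound 3 (within the scatter). Among these compounds, this is the first look at this nitrogen, as the earlier pair differed only at an aromatic carbon, and it shows that an open propyl chain can give way to a four-membered ring of carbon without any step beyond the scatter in this read-out. So for compound 2 and compound 3, the change from chain to ring on the nitrogen leaves the percent of compound remaining where it was, in contrast to the large step seen with methoxy in place of methyl; nothing available explains why this swap leaves the reading unchanged.

As far as these compounds go, whether cyclobutyl would read the same alongside the methyl group of compound 1 remains open, as this single pair speaks only for the methoxy series. Also open, from the compounds shown here alone, is how this assay would respond to other groups on the same nitrogen, such as cyclopentyl, a longer chain or a chain carrying an ether oxygen.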